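The source may report more compounds than this note shows. Statements on the series, on what has been measured and on what is new or still open speak of the compounds shown alone.

Measured so far in a functional assay on CHO cells for activation of 5-hydroxytryptamine receptor 1D (Homo sapiens), read by GTPgammaS binding; on this read-out lower numbers stand for an effect already at smaller amounts and higher numbers for an effect only at larger amounts of compound:
- compound 1, `c1ccc(CN2CCN(CCCc3c[nH]c4ccc(-n5cnnc5)cc34)CC2)nc1`, gives 0.3 nM
- compound 2, `c1cc(CN2CCN(CCCc3c[nH]c4ccc(-n5cnnc5)cc34)CC2)ccn1`, gives 1 nM
- compound 3, `c1coc(CN2CCN(CCCc3c[nH]c4ccc(-n5cnnc5)cc34)CC2)c1`, gives 0.5 nM

Compound 3 stands second highest of the three numbers in this assay; its nearest neighbour is compound 1, with a 1.7-fold higher number from compound 1 to compound 3 (0.22 log units; within the scatter), and its furthest is compound 2, with a 2.0-fold lower number from compound 2 to compound 3 (0.30 log units; within the scatter), both within the scatter. The next compound, compound 4, `CC(=O)Nc1ccc(CN2CCN(CCCc3c[nH]c4ccc(-n5cnnc5)cc34)CC2)cc1`, carries the change (4-acetamidophenyl in place of furan-2-yl on a saturated chain carbon bound to an amine nitrogen in a ring). Within the data shown here, no measured step replaces the furan-2-yl with a six-membered ring of carbon only, so the bearing steps are indirect: the three exchanges of the group on this chain carbon gave a 1.7-fold higher number from compound 1 to compound 3 (0.22 log units; within the scatter), a 2.0-fold lower number from compound 2 to compound 3 (0.30 log units; within the scatter) and, the only one beyond the scatter, a 3.3-fold higher number from compound 1 to compound 2 (0.52 log units; beyond the scatter), which was modest. On that basis the group at this position is expected to move the number only a little, so the step of a 1.4-fold higher number from compound 3 to compound 4 (0.15 log units; within the scatter) is estimated to stay within the scatter, with a slight chance of a modest rise. Compound 4 is therefore expected to give 0.7 nM, within a range of 0.2 nM to 2.5 nM.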

Compound 4, half-maximal effective concentration: 6.1 nM
Compound 4: middle estimate off by 8.7-fold (0.94 log units), on the low side; measured number above the stated range.
By their numbers in this assay, from the lowest: compounds 1, 3 and 2 (each within the scatter of the next, the first and the last beyond it); then compound 4.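

In this assay the group on this saturated chain carbon bound to an amine nitrogen in a ring proves able to move the number a long way: 4-acetamidophenyl gives a 12-fold higher number from compound 3 to compound 4 (1.09 log units; beyond the scatter) against furan-2-yl, a 20-fold higher number from compound 1 to compound 4 (1.31 log units; beyond the scatter) against pyridin-2-yl and a 6.1-fold higher number from compound 2 to compound 4 (0.79 log units; beyond the scatter) against pyridin-4-yl. Exchanges among the three earlier groups had left the number nearly flat, with only a 3.3-fold higher number from compound 1 to compound 2 (0.52 log units; beyond the scatter) beyond the scatter, and that tolerance does not extend to 4-acetamidophenyl. No evidence at hand bears on what lies behind this rise. The compounds shown leave open whether the rise goes with the six-membered ring of carbon only or with the acetamido part on it. A plain phenyl or a 4-aminophenyl at this place would separate the two.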